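The compounds below may be only part of what the source reports. "The series", "measured", "known", "first", "only" and "open" are said of these compounds alone.

Measured so far:
compound 1 `Cc1cnc(C(=O)Nc2cc(F)cc3cccnc23)cn1` — > 10000 nM
compound 2 `COc1cc(NC(=O)c2cnc(C)cn2)c2ncccc2c1` — 6700 nM

In a functional assay on BXPC-3 cells (Homo sapiens) for inhibition, read by MTT assay, with a stated time of 72 h (on this read-out lower numbers stand for stronger inhibition and higher numbers for weaker inhibition), compound 1 gives > 10000 nM, which is a limit of the assay and not a number; compound 1 therefore stands only at a floor (the limit of > 10000 nM in this assay, at which 1 of the 2 values shown sits). In this assay, among the measured compounds shown here, compound 2 gives 6700 nM, and the one measured step is an at least 1.4-fold lower number from compound 1 to compound 2 (0.17 log units; that floor lies within the scatter), a methoxy for fluoro exchange. Compound 3 `O=C(Nc1cc(F)cc2cccnc12)c1cnccn1` differs from compound 1 by hydrogen in place of methyl on an aromatic carbon. For the measured compounds named here, no measured step touches the methyl, so nothing here sets a size or direction for its loss. With compound 1 at the limit, compound 3 is expected to sit near that limit as well, estimated at 15000 nM (range 5000 nM to 50000 nM), an expected step that the limit leaves unreadable from compound 1 to compound 3.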

Compound 3, half-maximal inhibitory concentration: > 10000 nM
Compound 3 was reported as a limit (the forecaster's own chance of this, stated with the estimate: 70%); the middle value lies beyond the limit too.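

Compound 1 and compound 3 both stand at a limit and not at a number, so no step between them can be read: the limit of > 10000 nM in this assay, at which 2 of the 3 values shown sit.

Going by these compounds, whether the change from 5-methylpyrazin-2-yl to pyrazin-2-yl shifts inhibition at all, in size or direction, stays open.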